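A few compounds are considered here, and "the series" means these few. Any claim that something is new, unique, unknown or untested is made for them only; others in the source may bear on it.

Working notes on the aryl-substituted series.

Compound 1, `CCCS(=O)(=O)Nc1ccc(F)c(C(=O)c2n[nH]c3ncc(-c4ccc(C)cc4)cc23)c1F`, carries a 4-methylphenyl group on the shared core. In an assay for binding affinity to dual specificity mitogen-activated protein kinase kinase 4 (Homo sapiens), read by KINOMEscan, tested at 100 nM (a higher number here means a weaker effect of the compound at the concentration tested, a lower number a stronger effect), compound 1 gives 5.4%. Compound 2, `CCCS(=O)(=O)Nc1ccc(F)c(C(=O)c2n[nH]c3ncc(-c4ccc(N(C)C)cc4)cc23)c1F`, carries a dimethylamino in place of the methyl on the same aromatic carbon; in this assay compound 2 gives 2.5%. Going by the values given here, the one measured step is a number 2.9 percentage points lower from compound 1 to compound 2 (within the scatter). Among the compounds with values here, compound 1 therefore stands with the highest of the two numbers so far, its nearest neighbour being compound 2, and the two values do not separate from each other.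

Compound 3, `CCCS(=O)(=O)Nc1ccc(F)c(C(=O)c2n[nH]c3ncc(-c4ccc(C(C)(C)C)cc4)cc23)c1F`, is not yet measured in this assay. Against compound 1 the difference is tert-butyl in place of methyl on an aromatic carbon. Within the data shown here, the only measured step that bears on it is the one from compound 1 to compound 2, which exchanges a group at the same aromatic carbon and stays within the scatter. No step beyond the scatter is therefore expected in this assay; the change from compound 1 to compound 3 is estimated as a number 1.6 percentage points higher from compound 1 to compound 3 (within the scatter). For compound 3 the expected value in this assay is 7%, with a range from 1% to 20%.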

Compound 3, a percentage reported as activity, at one concentration (the size of the read-out at that concentration, not a potency): 46%
Beside the measured number, compound 3's estimate is 39 percentage points below it, and the stated range ends below it.
By their numbers in this assay, from the lowest: compounds 2 and 1 (each within the scatter of the next); then compound 3.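

The aromatic carbon para to a large group is not indifferent to what it carries: in this assay tert-butyl in place of methyl gives a number 40.6 percentage points higher from compound 1 to compound 3 (beyond the scatter) and a weaker effect at the concentration tested, and tert-butyl in place of dimethylamino gives a number 43.5 percentage points higher from compound 2 to compound 3 (beyond the scatter) with the same outcome. The agreement between methyl and dimethylamino therefore does not extend to every group at this carbon, and the earlier pair gave no sign of this limit. In the computed difference from methyl to tert-butyl, the heavy atoms go from 1 to 4, with no hydrogen-bond donor, acceptor or net charge on either side, but no measurement at hand accounts for the step.

Ethyl and isopropyl at the same carbon would show whether the number climbs gradually from methyl to tert-butyl or rises only with tert-butyl itself. Going by these compounds, whether other groups of similar size, such as a morpholine or a cyclohexyl ring, are treated as tert-butyl is or as dimethylamino is remains open.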